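The source may report more compounds than this note shows. Statements on the series, on what has been measured and on what is new or still open speak of the compounds shown alone.

Of the compounds shown here, two of a shared core have been measured in a functional assay on A549 cells (Homo sapiens) for cytotoxicity, read by MTT assay, with a stated time of 24 h; a lower number here means a stronger inhibitor, a higher number a weaker inhibitor. Compound 1, `Cc1ncc([N+](=O)[O-])n1CCOc1ccccc1Cl`, gives in this assay 574 ug/mL. Compound 2, `Cc1ncc([N+](=O)[O-])n1CCOc1ccc(Cl)c(Cl)c1`, gives in this assay 77.9 ug/mL. Of these two numbers, compound 2 holds the lower one, and the gap between compound 2 and compound 1 lies beyond the scatter of repeated measurements, so compound 2 stands as the stronger of the pair.

The next step in the series leads to compound 3, `Cc1cc(OCCn2c([N+](=O)[O-])cnc2C)ccc1Cl`, which has not yet been measured. The change from compound 2 to compound 3 is methyl in place of chloro on an aromatic carbon, the chloro group leaving and a methyl entering on the aromatic carbon that sits ortho to the remaining chloro group and meta to the large group. Among the measured compounds shown here, no measured pair in the set shows this exact exchange, so nothing is known here about its size.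

Given the value of compound 2, 77.9 ug/mL, the step expected from compound 2 to compound 3 is a 1.5-fold higher number from compound 2 to compound 3 (0.19 log units; within the scatter), a modest move toward a higher number that may well fall inside the scatter. Compound 3 is therefore estimated at 120 ug/mL in this assay, with a range from 50 ug/mL to 300 ug/mL.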

Compound 3, half-maximal inhibitory concentration: 150 ug/mL
Compound 3: the middle estimate sits 1.3-fold (0.10 log units) below what was measured; the measured number falls inside the stated range.
By their numbers in this assay, from the lowest: compounds 2 and 3 (each within the scatter of the next); then compound 1.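

In this assay, among the compounds shown here, the exchange of chloro for methyl on the aromatic carbon that sits ortho to the remaining chloro group and meta to the large group is a 1.9-fold higher number from compound 2 to compound 3 (0.28 log units; within the scatter), the first single exchange that can be read. For the compounds shown here, at this position, then, methyl can stand in place of chloro with no difference that clears the scatter of repeated measurements, something the earlier compounds could not show. Nothing at hand accounts for how closely compound 2 and compound 3 agree, and this one pair supports no wider rule about the position.

As far as these compounds go, what a methoxy group, an amine or a longer alkyl chain on this same aromatic carbon would give in this assay remains open. Also open, from the compounds shown here alone, is what would follow if the remaining chloro group gave way to fluoro or a nitrile while the methyl stayed in place.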